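Series notes: the step from compound 3 to compound 4

A few compounds are considered here, and "the series" means these few. Any claim that something is new, unique, unknown or untested is made for them only; others in the source may bear on it.

Three compounds have numbers in a functional assay on PC-3 cells (Homo sapiens) for antiproliferative activity, read by MTT assay, with a stated time of 72 h; a lower number here means a stronger inhibitor, a higher number a weaker inhibitor. Compound 1 `CC(C)(C)c1ccc(/C=C/C(=O)c2ccc(OCC(=O)N[C@H]3CCOC3=O)cc2)cc1` gives 10600 nM, compound 2 `O=C(COc1ccc(C(=O)/C=C/c2cccc(Br)c2)cc1)N[C@H]1CCOC1=O` gives 7890 nM, and compound 3 `O=C(COc1ccc(C(=O)/C=C/c2cccc(F)c2)cc1)N[C@H]1CCOC1=O` gives 23200 nM, the highest of the three; the steps of a 2.2-fold higher number from compound 1 to compound 3 (0.34 log units; beyond the scatter) and a 2.9-fold higher number from compound 2 to compound 3 (0.47 log units; beyond the scatter) are both beyond the scatter. Compound 4 `O=C(COc1ccc(C(=O)/C=C/c2ccc(Br)cc2)cc1)N[C@H]1CCOC1=O` differs from compound 3 in that (4-bromophenyl in place of 3-fluorophenyl on a double-bonded chain carbon bound to a double-bonded chain carbon). Within the data shown here, two measured steps bear on this: a 2.9-fold higher number from compound 2 to compound 3 (0.47 log units; beyond the scatter) covers the fluoro-to-bromo part in reverse, and a 1.3-fold lower number from compound 1 to compound 2 (0.13 log units; within the scatter) shows that exchanging 3-bromophenyl and 4-(tert-butyl)phenyl stays within the scatter. Among the measured compounds shown here, no measured pair covers 3-bromophenyl against 4-bromophenyl. A modest fall in this assay is therefore expected. Compound 4 is expected to give 8000 nM, from 3500 nM to 18000 nM. The expected step is a 2.9-fold lower number from compound 3 to compound 4 (0.46 log units; beyond the scatter).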

Compound 4, half-maximal inhibitory concentration: > 64000 nM
Compound 4: only a limit was reported; the forecaster's own chance of this, stated with the estimate: 5%; middle value at least 8.0-fold (0.90 log units) from the limit.
By their numbers in this assay, from the lowest: compounds 2 and 1 (each within the scatter of the next); then compound 3. At a limit, above all of these: compound 4.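

In this assay the reading of compound 4 is a limit and not a number: the limit of > 64000 nM in this assay, at which 1 of the 4 values shown sits. Among these compounds, the change to 4-bromophenyl from 3-bromophenyl is the first at this place to reach a step of this size, an at least 8.1-fold higher number from compound 2 to compound 4 (0.90 log units; beyond the scatter), and the loss also holds against 3-fluorophenyl, an at least 2.7-fold higher number from compound 3 to compound 4 (0.44 log units; beyond the scatter). A group named with 4- does not by itself give this outcome, since 4-(tert-butyl)phenyl still gives a number, an at least 6.0-fold higher number from compound 1 to compound 4 (0.78 log units; beyond the scatter).

From the compounds shown here alone, the full size of these steps stays open. So does whether 4-chlorophenyl, or an amine on that ring, follows 4-bromophenyl or 4-(tert-butyl)phenyl.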